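This account rests on a few compounds, and the source may have more. Where it says the series, first, only, none or still open, it means among the compounds named here.

Compound 1 `CC[C@H](C)[C@H](NC(=O)N1CCC2(CC1)C(=O)N(c1cccc(F)c1)C2c1ccc(Cl)cc1)C(=O)OC`: 45 nM; 872 nM (2 entries)
Compound 2 `CC[C@H](C)[C@H](NC(=O)N1CCC2(CC1)C(=O)N(c1cccc(F)c1)C2c1ccc(Cl)cc1)C(=O)OC(C)C`: 45 nM
Compound 3 `COC(=O)[C@H](C)NC(=O)N1CCC2(CC1)C(=O)N(c1cccc(F)c1)C2c1ccc(Cl)cc1`: 827 nM

In an assay on HEK293 cells for inhibition of Voltage-dependent T-type calcium channel subunit alpha-1H (Homo sapiens), read by patch clamp, using a membrane potential dye (a lower number here means a stronger inhibitor, a higher number a weaker inhibitor), compound 3 gives 827 nM, the highest of the two single numbers available; compound 2 sits well below it, while compound 1 has two entries that disagree with each other (the several entries of compound 1 in this assay, 45 nM; 872 nM (2 entries)). Going by the values given here, the only measured step that bears on the present question is an 18-fold higher number from compound 2 to compound 3 (1.26 log units; beyond the scatter), a large loss that came from shrinking the ester and the side chain at once. Compound 4 `COC(=O)[C@H](CO)NC(=O)N1CCC2(CC1)C(=O)N(c1cccc(F)c1)C2c1ccc(Cl)cc1` carries hydroxy in place of hydrogen on a saturated chain carbon, two bonds along the chain from an amide-type nitrogen and a carbonyl carbon. Among the compounds with values here, no measured step alters the side chain alone, so the direction is uncertain; only a modest step is expected, a 1.2-fold higher number from compound 3 to compound 4 (0.08 log units; within the scatter). Compound 4 is therefore estimated to give about 1000 nM, within 300 nM to 3500 nM.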

Compound 4, half-maximal inhibitory concentration: 3330 nM
For compound 4 the middle estimate is 3.3-fold (0.52 log units) below the measured one; the range from low to high includes it.
By their numbers in this assay, from the lowest: compound 2; then compound 3; then compound 4.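

In this assay, going from methyl to hydroxymethyl at this saturated chain carbon is not a neutral change: it gives a 4.0-fold higher number from compound 3 to compound 4 (0.60 log units; beyond the scatter), so one added hydroxy is enough to weaken inhibition. Measured against the larger group on the amide-type nitrogen, the gap reaches a 74-fold higher number from compound 2 to compound 4 (1.87 log units; beyond the scatter). Nothing shown here accounts for this loss. Still open, going by these compounds, is whether any added atom at this carbon costs as much, as a methoxy, an amine or a fluorine would show. Also open, on these data alone, is whether hydroxy has the same effect on a longer chain.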